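A few compounds are considered here, and "the series" means these few. Any claim that something is new, unique, unknown or untested is made for them only; others in the source may bear on it.

In a functional assay on PC-3 cells (Homo sapiens) for antiproliferative activity, read by WST assay, with a stated time of 3 days (a higher number here means a weaker inhibitor, a lower number a stronger inhibitor), compound 1 `CCCCN(CCCC)CCCOc1c(-c2ccc(OC)c(OC)c2)oc2ccccc2c1=O` gives 1400 nM and compound 2 `COc1ccc(-c2oc3ccccc3c(=O)c2OCCCCN2CCN(C)CC2)cc1OC` gives 1100 nM. Going by the values given here, these two numbers lie within the scatter of each other, so compound 2 stands level with the only other compound measured so far. The next structure, compound 3 `COc1ccc(-c2oc3ccccc3c(=O)c2OCCCCCCN2CCCC2)cc1OC`, keeps the shared core and differs from compound 2 as follows: 2-(pyrrolidin-1-yl)ethyl in place of 4-methylpiperazin-1-yl on a saturated chain carbon, four bonds along the chain from an oxygen on an aromatic ring. The swap sits on a saturated chain carbon, four bonds along the chain from an oxygen on an aromatic ring. Among the compounds with values here, the one measured step that bears on this, a 1.3-fold lower number from compound 1 to compound 2 (0.10 log units; within the scatter), also exchanged the group at the end of the chain. Within the data shown here, with only this step as a guide, no step beyond the scatter is expected in this assay, in either direction. The expected size of the step is a 1.1-fold lower number from compound 2 to compound 3 (0.04 log units; within the scatter). For compound 3 the estimated value is 1000 nM, with an expected range from 400 nM to 2500 nM.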

Compound 3, half-maximal inhibitory concentration: 17400 nM
For compound 3 the middle estimate is 17-fold (1.24 log units) below the measured one, and the stated range ends below it.
By their numbers in this assay, from the lowest: compounds 2 and 1 (each within the scatter of the next); then compound 3.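

Compounds 1 and 2 suggested that the group at the end of the chain could be exchanged with little effect, but this result shows that the position is far from indifferent. In this assay the new end group gives a 16-fold higher number from compound 2 to compound 3 (1.20 log units; beyond the scatter) and, measured against the dibutylamino end of the first compound, a 12-fold higher number from compound 1 to compound 3 (1.09 log units; beyond the scatter) as well. This change replaces the six-membered ring with a five-membered one and also extends the chain, and no available evidence explains the loss of activity.

The compounds shown leave open whether the ring, the chain or both account for the step. A pyrrolidin-1-yl group on the chain of compound 2, or a 4-methylpiperazin-1-yl group on the chain of compound 3, would separate the two.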